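Changing the Ring on the Sulfonyl Sulfur

A few compounds are considered here, and "the series" means these few. Any claim that something is new, unique, unknown or untested is made for them only; others in the source may bear on it.

Three compounds have so far been measured in an assay on isolated protein for inhibition of phosphoenolpyruvate carboxykinase, cytosolic [GTP] (Homo sapiens); a higher number here means a weaker inhibitor, a lower number a stronger inhibitor:

Compound 1, `CCCCn1c(=O)n(Cc2ccccc2F)c(=O)c2[nH]c(Cc3ccc(N)cc3)nc21`, gives 2560 nM.
Compound 2, `Cc1nc(N)sc1S(=O)(=O)Nc1ccc(Cc2nc3c([nH]2)c(=O)n(Cc2ccccc2F)c(=O)n3CC2CC2)cc1`, gives 230 nM.
Compound 3, `O=c1c2[nH]c(Cc3ccc(NS(=O)(=O)c4cccnc4)cc3)nc2n(CC2CC2)c(=O)n1Cc1ccccc1F`, gives 1950 nM.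

Compound 3 stands second highest of these three numbers in this assay; its value and that of compound 1 lie within the scatter of each other, while compound 2 is clearly lower, that is, the stronger inhibitor. Compound 4 is `Cc1nn(C)cc1S(=O)(=O)Nc1ccc(Cc2nc3c([nH]2)c(=O)n(Cc2ccccc2F)c(=O)n3CC2CC2)cc1`. It differs from compound 3 in one place: 1,3-dimethyl-1H-pyrazol-4-yl in place of pyridin-3-yl on a sulfonyl sulfur. Among the measured compounds shown here, only one measured step touches this spot, namely an 8.5-fold higher number from compound 2 to compound 3 (0.93 log units; beyond the scatter), and it shows that the ring on the sulfonyl sulfur can move the number well beyond the scatter. For the measured compounds named here, the ring entering in compound 4 is, like the one in compound 2, a five-membered aromatic ring carrying a methyl, but it lacks the amino group of compound 2. The expected outcome is therefore a number for compound 4 between those of compound 2 and compound 3, an expected step of a 2.2-fold lower number from compound 3 to compound 4 (0.34 log units; beyond the scatter) in this assay toward a stronger inhibitor. Compound 4 is estimated at 900 nM, with a range from 300 nM to 3000 nM.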

Compound 4, half-maximal inhibitory concentration: 240 nM
Compound 4: the middle estimate sits 3.8-fold (0.57 log units) above what was measured; the measured number lies below the stated range.
By their numbers in this assay, from the lowest: compounds 2 and 4 (each within the scatter of the next); then compounds 3 and 1 (each within the scatter of the next).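

In this assay, replacing pyridin-3-yl with 1,3-dimethyl-1H-pyrazol-4-yl on the sulfonyl sulfur gives an 8.1-fold lower number from compound 3 to compound 4 (0.91 log units; beyond the scatter) and so shows that a second ring can lower the number well beyond the scatter. The comparison with the aminothiazole ring gives a 1.0-fold higher number from compound 2 to compound 4 (0.02 log units; within the scatter) and shows that, in this pair, a ring without an amino group matches the one that has it. No measurement shown here accounts for the gap between these rings.

Among the compounds shown here, with only three rings at this position, ring size, the methyl groups and the ring nitrogens cannot be told apart. A pyrazol-4-yl ring without its two methyl groups, or a plain phenyl ring on the same sulfur, would help to separate these features.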